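Cyano for chloro on a second thiazolylamino core

The source may hold more compounds than are shown below. What is called first, only, known or untested is meant among the compounds shown, and "the series" means these compounds.

Measured compounds:
compound 1, `CC(C)=CCOc1cc(Nc2nccs2)ccc1Cl`, 26000 nM
compound 2, `CC(C)=CCOc1cc(Nc2nccs2)ccc1C#N`, 750 nM
compound 3, `Clc1ccc(Nc2nccs2)cc1OCc1nccs1`, 20000 nM

In a functional assay on MT2 cells (Homo sapiens) for cytotoxicity, read by MTT assay (on this read-out higher numbers stand for lower toxicity in this test and lower numbers for higher toxicity in this test), compound 1 gives 26000 nM, and compound 2 gives 750 nM. Their difference is cyano in place of chloro on an aromatic carbon, and the step is a 35-fold lower number from compound 1 to compound 2 (1.54 log units; beyond the scatter). Compound 3 differs from compound 1 by 1,3-thiazol-2-yl in place of 2-methylprop-1-en-1-yl on a saturated chain carbon bound to an oxygen on an aromatic ring, with a 1.3-fold lower number from compound 1 to compound 3 (0.11 log units; within the scatter). Compound 4, `N#Cc1ccc(Nc2nccs2)cc1OCc1nccs1`, is not yet measured. It stands to compound 3 as compound 2 stands to compound 1: cyano in place of chloro on an aromatic carbon. The surroundings are not identical, since here the new group sits ortho to a group of 7 heavy atoms rather than ortho to a (3-methylbut-2-en-1-yl)oxy group (6 heavy atoms), so this is the same kind of change rather than the same change. Because the earlier step was a 35-fold lower number from compound 1 to compound 2 (1.54 log units; beyond the scatter) on a core that tracks compound 3 closely, a step of similar size is expected here, a 29-fold lower number from compound 3 to compound 4 (1.46 log units; beyond the scatter), slightly tempered for the altered surroundings. Compound 4 is therefore estimated at 700 nM, between 250 nM and 2500 nM.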

Compound 4, half-maximal cytotoxic concentration: 20000 nM
Estimate against measurement, compound 4: 29-fold (1.46 log units) below; measured number outside the range, above it.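

In this assay, the step on the core of compound 3 reads no change at the digits printed from compound 3 to compound 4 (within the scatter), so cyano in place of chloro does not repeat on this core what it gave on the core of compound 1: the same change on two cores in this assay, a 35-fold lower number (1.54 log units; beyond the scatter) from compound 1 to compound 2 and no change at the digits printed (within the scatter) from compound 3 to compound 4, 35-fold (1.54 log units) apart, beyond the scatter of two such steps Read the other way, 1,3-thiazol-2-yl in place of 2-methylprop-1-en-1-yl gives a 27-fold higher number from compound 2 to compound 4 (1.43 log units; beyond the scatter), although the same change left the chloro pair within the scatter: the same change on two cores in this assay, a 1.3-fold lower number (0.11 log units; within the scatter) from compound 1 to compound 3 and a 27-fold higher number (1.43 log units; beyond the scatter) from compound 2 to compound 4, 35-fold (1.54 log units) apart, beyond the scatter of two such steps The size of the cyano step therefore depends on the core in these four compounds, but a single pair of cores does not show why, or how the change would behave on any other core.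

The compounds shown leave open whether a benzyl or cyclopropylmethyl group on the oxygen would follow compound 2 or compound 4. They also leave open how a carboxamide or a methyl group in place of the cyano group would read on either core.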